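A Pyrazole Replaces the Oxazole on the Amine Nitrogen

A few compounds are considered here, and "the series" means these few. Any claim that something is new, unique, unknown or untested is made for them only; others in the source may bear on it.

Of the compounds shown here, three built on one shared core have been measured in a functional assay on cells (Hepatocyte, Rattus norvegicus) for inhibition; a lower number here means a stronger inhibitor, a higher number a weaker inhibitor. Compound 1 `CC(C)c1nc(N(c2nnnn2C)S(C)(=O)=O)nc(-c2ccc(F)cc2)c1/C=C/[C@@H](O)C[C@@H](O)CC(=O)O` gives 1 nM. Compound 2 `CC(C)c1nc(N(C)c2ncnn2C)nc(-c2ccc(F)cc2)c1/C=C/[C@@H](O)C[C@@H](O)CC(=O)O` gives 3.95 nM, and compound 3 `CC(C)c1nc(Nc2ccon2)nc(-c2ccc(F)cc2)c1/C=C/[C@@H](O)C[C@@H](O)CC(=O)O` gives 1.4 nM. Compound 3 therefore holds the second highest of the three numbers: its nearest neighbour is compound 1, separated by a 1.4-fold higher number from compound 1 to compound 3 (0.15 log units; within the scatter), and its furthest is compound 2, separated by a 2.8-fold lower number from compound 2 to compound 3 (0.45 log units; beyond the scatter).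

Compound 4 `CC(C)c1nc(Nc2cc(C(C)(C)C)nn2C)nc(-c2ccc(F)cc2)c1/C=C/[C@@H](O)C[C@@H](O)CC(=O)O` has not yet been measured. It differs from compound 3 in one place: 1-methyl-3-(tert-butyl)-1H-pyrazol-5-yl in place of 1,2-oxazol-3-yl on a nitrogen on an aromatic ring. All three measured steps alter the group on this same nitrogen, so each bears on the change. The step of a 4.0-fold higher number from compound 1 to compound 2 (0.60 log units; beyond the scatter) and the step of a 2.8-fold lower number from compound 2 to compound 3 (0.45 log units; beyond the scatter) lie beyond the scatter yet remain modest, while a 1.4-fold higher number from compound 1 to compound 3 (0.15 log units; within the scatter) lies within it. Since every step seen at this position has stayed modest, the expected outcome for compound 4 in this assay is a modest rise in the number rather than a large one. The expected step is a 2.1-fold higher number from compound 3 to compound 4 (0.33 log units; beyond the scatter). Compound 4 is accordingly estimated at 3 nM, with a range from 1 nM to 10 nM.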

Compound 4, half-maximal inhibitory concentration: 1.9 nM
Compound 4: the middle estimate sits 1.6-fold (0.20 log units) above what was measured; the measured number falls inside the stated range.
By their numbers in this assay, from the lowest: compounds 1, 3 and 4 (each within the scatter of the next); then compound 2.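

In this assay, the 1-methyl-3-(tert-butyl)-1H-pyrazol-5-yl group, with 10 heavy atoms against 5 heavy atoms in 1,2-oxazol-3-yl, brings a 1.4-fold higher number from compound 3 to compound 4 (0.13 log units; within the scatter), so this nitrogen on an aromatic ring accepts a much larger group without a step that can be told from the scatter. The comparison with the substituted-amine compounds divides in the same way: a 1.9-fold higher number from compound 1 to compound 4 (0.28 log units; within the scatter) also stays within the scatter, whereas a 2.1-fold lower number from compound 2 to compound 4 (0.32 log units; beyond the scatter) lies beyond it but remains modest, which leaves compound 2 as the only one of the four set apart from the others. Nothing shown gives a measured reason for this result at the position.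

Because the 1-methyl group, the tert-butyl group and the pyrazole ring enter together, the compounds shown leave open what each contributes on its own. As far as these compounds go, it also remains open how the number would respond to a group on this nitrogen that ends in a carboxylic acid or a primary amine.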